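The source may report more compounds than this note shows. Statements on the series, on what has been measured and on what is new or still open speak of the compounds shown alone.

Measured compounds:
compound 1 `CCOC(=O)C1=Cc2ccccc2OC1(OCc1cn(CC(=O)Nc2ccc(C)cc2)nn1)C(F)(F)F` gives 54300 nM in a functional assay on A549 cells (Homo sapiens) for inhibition, read by MTT assay, with a stated time of 24 h; a lower number here means a stronger inhibitor, a higher number a weaker inhibitor;
compound 2 `O=C(O)C1=Cc2ccccc2OC1(OCc1cc(-c2ccc(F)cc2F)no1)C(F)(F)F` in this assay reaches only a limit, > 150000 nM;
compound 3 `O=C(O)C1=Cc2ccccc2OC1(OCc1cc(-c2ccc3ccccc3c2)no1)C(F)(F)F` in this assay likewise reaches only a limit, > 150000 nM.

Compound 1 stands as the only number shown; the other two values sit at the limit of > 150000 nM in this assay, at which 2 of the 3 values shown sit. Going by the values given here, the one measured step, a step that the two limits leave unreadable from compound 2 to compound 3, concerns a change on an aromatic carbon and is unreadable. Compound 4 `CCOC(=O)C1=Cc2ccccc2OC1(OCc1cn(-c2cccc(OC)c2)nn1)C(F)(F)F` differs from compound 1 by 3-methoxyphenyl in place of ((4-methylphenyl)carbamoyl)methyl on an aromatic nitrogen. Among the compounds with values here, no measured step bears on a change at that aromatic nitrogen, so nothing supports a shift in this assay beyond the scatter in either direction. Compound 4 is therefore expected near compound 1, with a 1.1-fold higher number from compound 1 to compound 4 (0.04 log units; within the scatter), estimated at 60000 nM within 15000 nM to 150000 nM.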

Compound 4, half-maximal inhibitory concentration: > 150000 nM
Compound 4 ended at the assay's limit; the forecaster's own chance of this, stated with the estimate: 30%; middle value at least 2.5-fold (0.39 log units) from the limit.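

Going by these compounds alone, on the aromatic nitrogen, 3-methoxyphenyl in place of ((4-methylphenyl)carbamoyl)methyl gives an at least 2.7-fold higher number from compound 1 to compound 4 (0.44 log units; beyond the scatter) in this assay, the first readable step, so the group at this position does matter. Compound 4 stands at a limit of the assay, so the step is bounded on one side only. Compound 1 alone now carries a number: the limit of > 150000 nM in this assay, at which 3 of the 4 values shown sit.

From the compounds shown here alone, whether the carbamoyl link or the aromatic ring of the group in compound 1 matters stays open. A benzyl group or a longer chain ending in an amine on that nitrogen would separate the two.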